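Compound 1 and a change of fluorine pattern

This account rests on a few compounds, and the source may have more. Where it says the series, first, only, none or still open, it means among the compounds named here.

Values in a functional assay on A-375 cells (Homo sapiens) for activation, with a stated time of 3 days; a lower number here means that less compound is needed, a higher number that more compound is needed for the effect:
- Compound 1 `O=C(Nc1ccc(-c2cscn2)cc1)C1CCCN(Cc2ccc(F)c(F)c2)C1`: 1240 nM
- Compound 2 `O=C(Nc1ccc(-c2cscn2)cc1)C1CCCN(S(=O)(=O)c2ccc(F)c(F)c2)C1`: > 20000 nM (a limit of the assay, not a number)
- Compound 3 `O=C(Nc1ccc(-c2cscn2)cc1)[C@H]1CCCN(Cc2ccc(F)c(F)c2)C1`: 270 nM

Of the two actual numbers in this assay, compound 1 has the higher, and compound 3 is its nearest neighbour. The third result is only a limit, (the limit of > 20000 nM in this assay, at which 1 of the 3 values shown sits).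

Compound 4 `O=C(Nc1ccc(-c2cscn2)cc1)C1CCCN(Cc2ccccc2F)C1` keeps the core of compound 1 and differs at one place: 2-fluorophenyl in place of 3,4-difluorophenyl on a saturated chain carbon bound to an amine nitrogen in a ring. In words, 2-fluorophenyl stands in place of 3,4-difluorophenyl on a saturated chain carbon bound to an amine nitrogen in a ring.

Among the measured compounds shown here, only one measured step is available, a 4.6-fold lower number from compound 1 to compound 3 (0.66 log units; beyond the scatter). That step goes with the fact that one of compounds 1 and 3 is drawn with a defined configuration and the other without, at the place where they differ, and it leaves the 3,4-difluorophenyl group untouched. Compound 4 is drawn without a configuration at that stereocentre, as compound 1 is, so this step does not transfer to the new comparison. For the measured compounds named here, no measured step changes the fluorine pattern, so neither the size nor the direction of the effect can be read from the data. The expectation therefore starts from compound 1 at 1240 nM, with no change beyond the scatter foreseen and a wide range allowed.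

The expected step is a 1.1-fold higher number from compound 1 to compound 4 (0.05 log units; within the scatter).

For compound 4 the estimated value is 1400 nM, with an expected range from 450 nM to 4500 nM.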

Compound 4, half-maximal effective concentration: 7000 nM
Estimate against measurement, compound 4: 5.0-fold (0.70 log units) below; the whole stated range lies below it.
By their numbers in this assay, from the lowest: compound 3; then compound 1; then compound 4. At a limit, above all of these: compound 2.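

In this assay, among the compounds shown here, the aryl group on a saturated chain carbon bound to an amine nitrogen in a ring proves sensitive to its fluorine pattern: 2-fluorophenyl in place of 3,4-difluorophenyl gives a 5.6-fold higher number from compound 1 to compound 4 (0.75 log units; beyond the scatter) and is the first measured step at this group, which the earlier compounds all keep as 3,4-difluorophenyl. Compound 1 and compound 4 are both drawn without a configuration at the stereocentre, and the comparison is like for like in how they are drawn. The change removes one fluorine and alters the fluorine pattern at once, and the step cannot be divided between these two differences. None of the information at hand offers a reason for this step.

The compounds shown leave open whether a plain phenyl, a 3-fluorophenyl or a 3,4-dichlorophenyl group would lie nearer to compound 1 or to compound 4 in this assay series. From the compounds shown here alone, it also remains open whether the form of compound 4 drawn with the S configuration would give a lower number than compound 4, as compound 3 does relative to compound 1.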